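Triazole substituent series: phenyl to 2-fluorobenzyl

The compounds below may be only part of what the source reports. "The series", "measured", "known", "first", "only" and "open" are said of these compounds alone.

Compound 1 `COc1ccc([C@@H]2C/C(=N\O)c3c(O)cc(OCc4cn(C5CCCC5)nn4)cc3O2)cc1O` and compound 2 `COc1ccc([C@@H]2C/C(=N\O)c3c(O)cc(OCc4cn(-c5ccccc5)nn4)cc3O2)cc1O` share one core and differ only in the group carried on an aromatic nitrogen of the triazole ring. In a functional assay on RAW264.7 cells (Mus musculus) for inhibition, read by Griess assay, with stated times of 2 h and 24 h (on this read-out lower numbers stand for stronger inhibition and higher numbers for weaker inhibition), compound 1 gives 6880 nM, and in this assay compound 2 gives 6130 nM. For the measured compounds named here, the one step recorded so far, a 1.1-fold lower number from compound 1 to compound 2 (0.05 log units; within the scatter), shows that exchanging cyclopentyl for phenyl at this position left the read-out essentially unchanged. Compound 2 thus holds the lowest of the two numbers, but only with compound 1 at a gap that the scatter covers.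

Compound 3 `COc1ccc([C@@H]2C/C(=N\O)c3c(O)cc(OCc4cn(Cc5ccccc5F)nn4)cc3O2)cc1O` is the next member. Its difference from compound 2 is 2-fluorobenzyl in place of phenyl on an aromatic nitrogen. Going by the values given here, the only measured step that bears on this site is the cyclopentyl-to-phenyl exchange, and it was within the scatter; nothing further is known about substituents here. A similarly small step is therefore expected, a 1.1-fold higher number from compound 2 to compound 3 (0.03 log units; within the scatter), with no clear direction. Compound 3 is estimated to give 6500 nM in this assay, expected to lie between 3000 nM and 14000 nM.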

Compound 3, half-maximal inhibitory concentration: 5710 nM
Estimate against measurement, compound 3: 1.1-fold (0.06 log units) above; the measured number falls inside the stated range.
By their numbers in this assay, from the lowest: compounds 3, 2 and 1 (each within the scatter of the next).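

In this assay, the exchange of phenyl for 2-fluorobenzyl on an aromatic nitrogen of the five-membered aromatic ring with 3 nitrogen gives a 1.1-fold lower number from compound 2 to compound 3 (0.03 log units; within the scatter), and the exchange of cyclopentyl for 2-fluorobenzyl gives a 1.2-fold lower number from compound 1 to compound 3 (0.08 log units; within the scatter). The earlier pair covered only cyclopentyl and phenyl; this result extends the flat picture to a group of 8 heavy atoms that contains fluorine, against 6 heavy atoms for phenyl, so that all three compounds now stand within the scatter of one another and no order can be drawn among these groups. The data on hand offer no explanation for this flat read-out at the position.

Unsubstituted benzyl is absent from the compounds shown, so the fluorine cannot be separated from the rest of the 2-fluorobenzyl group in this comparison. Also open is whether a group of a different kind at this nitrogen, such as an amine, a carboxylic acid or a longer alkyl chain, would move the number beyond the scatter, since the three groups shown are all hydrocarbon rings or a fluorinated version of one.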